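Chloro in place of methyl: compound 2 to compound 3

The source may hold more compounds than are shown below. What is called first, only, known or untested is meant among the compounds shown, and "the series" means these compounds.

Measured so far in a functional assay on MGC-803 cells (Homo sapiens) for inhibition, read by MTT assay, with a stated time of 72 h; on this read-out lower numbers stand for stronger inhibition and higher numbers for weaker inhibition:
compound 1 `Cc1ccc(Nc2nc(SCc3cn(Cc4ccccc4Cl)nn3)nc(-c3ccccc3)c2C#N)cc1` gives 7190 nM
compound 2 `Cc1ccc(Nc2nc(SCc3cn(Cc4ccccc4Cl)nn3)nc(-c3ccc(C)cc3)c2C#N)cc1` gives 24400 nM

Compound 2 stands highest of the two numbers; the step of a 3.4-fold higher number from compound 1 to compound 2 (0.53 log units; beyond the scatter) separates it from compound 1. Compound 3 `Cc1ccc(Nc2nc(SCc3cn(Cc4ccccc4Cl)nn3)nc(-c3ccc(Cl)cc3)c2C#N)cc1` differs from compound 2 by chloro in place of methyl on an aromatic carbon. Among the measured compounds shown here, no measured step exchanges these two groups; the only measured step, a 3.4-fold higher number from compound 1 to compound 2 (0.53 log units; beyond the scatter), concerns methyl against hydrogen and gives no direct guide. For compound 3 no change beyond the scatter is expected in this assay, a step of a 1.6-fold lower number from compound 2 to compound 3 (0.21 log units; within the scatter). Compound 3 is estimated at 15000 nM, within 5000 nM to 45000 nM.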

Compound 3, half-maximal inhibitory concentration: 18500 nM
Estimate against measurement, compound 3: 1.2-fold (0.09 log units) below; low and high end bracket the measured number.
By their numbers in this assay, from the lowest: compound 1; then compounds 3 and 2 (each within the scatter of the next).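

In this assay, the change from 4-methylphenyl to 4-chlorophenyl gives a 1.3-fold lower number from compound 2 to compound 3 (0.12 log units; within the scatter), so methyl and chloro are not told apart at this place, para to a large group. Chloro in place of hydrogen gives a 2.6-fold higher number from compound 1 to compound 3 (0.41 log units; beyond the scatter), so the higher number seen with methyl is not confined to that group: compound 2 and compound 3 both stand above compound 1. No measured evidence on the series gives a reason for this.

On these data alone, whether any group here can match or improve on hydrogen stays open. An amine or a carboxylic acid at this place would test that.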